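A few compounds are considered here, and "the series" means these few. Any claim that something is new, unique, unknown or untested is made for them only; others in the source may bear on it.

Of the compounds shown here, two on one shared core have been measured so far. In an assay on HEK293 cells for displacement of a labelled ligand from corticotropin-releasing factor receptor 1 (Homo sapiens), read by scintillation counting, with a stated time of 2 h (on this read-out higher numbers stand for weaker inhibition and lower numbers for stronger inhibition), compound 1 `COCc1cc(OC)c(-c2cccc3c(N(CC4CCOCC4)CC4CC4)c(C)nn23)c(OC)c1` gives 120 nM, the higher of the two numbers, while compound 2 `CCc1nn2c(-c3c(C)cc(C)cc3OC)cccc2c1N(CC1CC1)CC1CCCO1` gives 34 nM, a gap beyond the usual scatter. Compound 3 `COCc1cc(OC)c(-c2cccc3c(N(CC4CCOCC4)CC4CC4)c(OC)nn23)c(OC)c1` is compound 1 with a single change: methoxy in place of methyl on an aromatic carbon. Among the measured compounds shown here, no measured pair shows what this change does, so the expectation rests on compound 1 alone. The step is expected to stay within the scatter, a 1.2-fold lower number from compound 1 to compound 3 (0.08 log units; within the scatter). Compound 3 is therefore estimated at 100 nM in this assay, within a range from 40 nM to 300 nM.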

Compound 3, half-maximal inhibitory concentration: 51 nM
Beside the measured number, compound 3's estimate is 2.0-fold (0.29 log units) above it; the measured number falls inside the stated range.
By their numbers in this assay, from the lowest: compounds 2 and 3 (each within the scatter of the next); then compound 1.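

Methoxy in place of methyl on an aromatic carbon gives a 2.4-fold lower number from compound 1 to compound 3 (0.37 log units; beyond the scatter) in this assay and so shows that this position, next to the ring nitrogen, accepts the larger group with a modest gain rather than a loss. Among the compounds shown here, this is the first measured change at this position on the shared core. No measured property accounts for the gain, and its cause remains unknown.

From the compounds shown here alone, whether the oxygen itself matters or the larger group alone is enough stays open. Ethoxy or an amine at this position could help to tell these apart.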